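A few compounds are considered here, and "the series" means these few. Any claim that something is new, unique, unknown or untested is made for them only; others in the source may bear on it.

Compounds measured in a functional assay on KB cells (Homo sapiens) for cytotoxicity (on this read-out lower numbers stand for stronger inhibition and higher numbers for weaker inhibition), so far:
compound 1 `COc1ccc(S(=O)(=O)N2CCc3cccc(NC(=O)c4ccc([N+](=O)[O-])cc4)c32)cc1` gives 95 nM
compound 3 `COc1ccc(S(=O)(=O)N2CCc3cccc(NC(=O)c4ccc(F)cc4)c32)cc1` gives 85 nM
compound 2 `COc1ccc(S(=O)(=O)N2CCc3cccc(NCc4ccccc4)c32)cc1` gives > 10000 nM

For compound 2 the value is not a number but a limit of this assay, so only a range is known for it. Compound 4 `COc1ccc(S(=O)(=O)N2CCc3cccc(NC(=O)c4ccccc4)c32)cc1` has not been measured; it differs from compound 2 by benzoyl in place of benzyl on a nitrogen on an aromatic ring. Two of the measured steps are relevant. The first is the same kind of change, seen on a neighbouring compound: an at least 110-fold lower number from compound 2 to compound 3 (2.07 log units; beyond the scatter). Since compound 2 sits at the limit of > 10000 nM in this assay, at which 1 of the 3 values shown sits, that step is itself only a lower bound. The second step, a 1.1-fold lower number from compound 1 to compound 3 (0.05 log units; within the scatter), shows that exchanging the group on the carbonyl-bearing ring barely moves the number, so compound 1 and compound 3 point to roughly the same region for a benzoyl on that nitrogen. Taken together, the expected step is a large one downward, estimated as an at least 110-fold lower number from compound 2 to compound 4 (2.04 log units; beyond the scatter). Compound 4 is therefore expected to give a value of about 90 nM, with a likely range from 35 nM to 250 nM.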

Compound 4, half-maximal inhibitory concentration: 180 nM
Compound 4: middle estimate off by 2.0-fold (0.30 log units), on the low side, and the stated range covers the measured number.
By their numbers in this assay, from the lowest: compounds 3, 1 and 4 (each within the scatter of the next, the first and the last beyond it). At a limit, above all of these: compound 2.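

In this assay, benzoyl in place of benzyl on the nitrogen gives an at least 55-fold lower number from compound 2 to compound 4 (1.74 log units; beyond the scatter), so the large change seen earlier does not need a fluoro or nitro group on the benzoyl ring. Compound 2 gives a limit rather than a number, so this step fixes only a minimum size: the limit of > 10000 nM in this assay, at which 1 of the 4 values shown sits. The ring substituent has a much smaller part in the picture: hydrogen in place of fluoro gives a 2.1-fold higher number from compound 3 to compound 4 (0.33 log units; beyond the scatter), a modest step, while hydrogen in place of nitro gives a 1.9-fold higher number from compound 1 to compound 4 (0.28 log units; within the scatter), which stays within the scatter.

The compounds shown carry only hydrogen, fluoro or nitro on the benzoyl ring, so it remains open how a methoxy group or an amine there would read out, and whether fluoro's modest edge over hydrogen would extend to other groups. Going by these compounds, it also remains open whether the change from benzylamino to benzamido depends on the benzoyl ring at all, which a small acetyl group on the same nitrogen would help to settle.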